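Dimethylamino in Place of Bromo: Expecting Another Limit

A few compounds are considered here, and "the series" means these few. Any claim that something is new, unique, unknown or untested is made for them only; others in the source may bear on it.

Of the compounds shown here, three sharing one core have been tested in an assay on isolated protein (Sus scrofa) for inhibition of prostacyclin synthase (Homo sapiens); a higher number here means a weaker inhibitor, a lower number a stronger inhibitor. Compound 1 `CC(C)c1c(Cn2ccnc2)c2ccccc2n1CCC(=O)O` gives > 100000 nM in this assay, which is a limit of the assay rather than a number. Compound 2 `O=C(O)CCn1cc(Cn2ccnc2)c2cc(Cl)ccc21` likewise gives only the limit > 100000 nM. Compound 3 `O=C(O)CCn1cc(Cn2ccnc2)c2cc(Br)ccc21` also sits at the limit > 100000 nM. The step that the two limits leave unreadable from compound 2 to compound 3 cannot be read, since the limit of > 100000 nM in this assay, at which 3 of the 3 values shown sit, covers all three values. Compound 4 `CN(C)c1ccc2c(c1)c(Cn1ccnc1)cn2CCC(=O)O` differs from compound 3 by dimethylamino in place of bromo on an aromatic carbon. Among the compounds with values here, no measured step bears on this change, as the only step between measured compounds, chloro to bromo, is unreadable. The expected step of a number no higher from compound 3 to compound 4 (the limit leaves the size open) in this assay is none beyond the scatter. Compound 4 is therefore estimated at 100000 nM, between 30000 nM and 300000 nM, most likely again a limit.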

Compound 4, half-maximal inhibitory concentration: > 100000 nM
Compound 4: no number, only a limit; the forecaster's own chance of this, stated with the estimate: 80%; the middle value lies on the limit itself.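

In this assay, within the data shown here, compound 4 gives > 100000 nM, again a limit and not a number, so no step from compound 2 or compound 3 to compound 4 can be read: the limit of > 100000 nM in this assay, at which 4 of the 4 values shown sit. The compounds shown leave open how strongly any of them inhibits the enzyme, and whether chloro, bromo or dimethylamino on the aromatic carbon makes any difference.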